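A few compounds are considered here, and "the series" means these few. Any claim that something is new, unique, unknown or untested is made for them only; others in the source may bear on it.

Compound 2 `CCOC(=O)c1ccc(/N=N/N(C)C(=O)[C@H](C)NC(C)=O)cc1` has been measured in a physicochemical assay for lipophilicity, read by HPLC, in phosphate buffer, measured as octanol-water partition, at pH 7.4 (on this read-out lower numbers stand for lower lipophilicity and higher numbers for higher lipophilicity), where compound 2 gives 2.52. Among the three compounds measured so far, compound 2 holds the second highest number. Its nearest neighbour is compound 1 `CC(=O)N[C@@H](C)C(=O)N(C)/N=N/c1ccc(Br)cc1`, which in this assay gives 2.8; the furthest is compound 3 `CCC(=O)N[C@@H](C)C(=O)N(C)/N=N/c1ccc(C#N)cc1`, which in this assay gives 1.87. Compound 1 and compound 2 differ in one place, and that step, a number 0.28 log units lower from compound 1 to compound 2 (within the scatter), lies within the scatter.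

Compound 4 `CC(=O)N[C@@H](C)C(=O)N(C)/N=N/c1ccc(C)cc1` has not yet been measured. It differs from compound 2 in one place: methyl in place of ethoxycarbonyl on an aromatic carbon. Among the measured compounds shown here, the only single-point step known here is the one from compound 1 to compound 2, which swaps the group at the same place on the aromatic ring and stays within the scatter; no measured step puts a methyl there. With so little to go on, the expectation for compound 4 in this assay is a step of about a number 0.03 log units higher from compound 2 to compound 4 (within the scatter), not beyond the scatter. Compound 4 is thus estimated at 2.55, within a range of 2.2 to 2.9.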

Compound 4, partition coefficient: 2.45
Beside the measured number, compound 4's estimate is 0.10 log units above it; measured number inside the range.
By their numbers in this assay, from the lowest: compound 3; then compounds 4, 2 and 1 (each within the scatter of the next, the first and the last beyond it).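

On this aromatic carbon, para to a large group, methyl in place of ethoxycarbonyl gives a number 0.07 log units lower from compound 2 to compound 4 (within the scatter), so in this assay a swap from five heavy atoms and two hydrogen-bond acceptors to one heavy atom and none leaves the read-out within the scatter. Methyl in place of bromo gives a number 0.35 log units lower from compound 1 to compound 4 (beyond the scatter), the first single-place step at this position that goes beyond the scatter, though only modestly, and compound 2 sits within the scatter of both of these compounds. Nothing measured here explains either step.

From the compounds shown here alone, whether an amine or a carboxylic acid at this position would stay as close to these three compounds remains open. So does whether a longer chain would, since only bromo, ethoxycarbonyl and methyl can be compared here.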